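The compounds below may be only part of what the source reports. "The series", "measured", "known", "first", "only" and "open" are said of these compounds alone.

Measured compounds:
compound 1 `O=C1NC(=O)/C(=C\c2ccc(OCC(=O)N3N=C(c4ccccc4)CC3c3ccc(Cl)c(Cl)c3)cc2)S1` — 700 nM
compound 2 `O=C1NC(=O)/C(=C\c2ccc(OCC(=O)N3N=C(c4ccc(F)cc4)CC3c3ccccc3)cc2)S1` — 4200 nM
compound 3 `Cc1ccc(C2CC(c3ccc(F)cc3)=NN2C(=O)COc2ccc(/C=C3/SC(=O)NC3=O)cc2)cc1` — 1800 nM

Three compounds sharing one core were measured in an assay on cells for inhibition of histone deacetylase 4 (Homo sapiens), read by fluorescence, with a stated time of 30 min; a higher number here means a weaker inhibitor, a lower number a stronger inhibitor. Compound 1 gives the lowest number of the three; compound 3 stands nearest with 1800 nM, and compound 2 furthest with 4200 nM, both gaps beyond the scatter. Compound 4 `O=C1NC(=O)/C(=C\c2ccc(OCC(=O)N3N=C(c4ccc(F)cc4)CC3c3ccc(Cl)c(Cl)c3)cc2)S1` has not yet been measured. It differs from compound 1 in one place: fluoro in place of hydrogen on an aromatic carbon, on an aromatic carbon of a six-membered aromatic ring of carbon only, para to a large group.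

Within the data shown here, no measured step covers this same change. Among the measured compounds shown here, the only single-place step known, a 2.3-fold lower number from compound 2 to compound 3 (0.37 log units; beyond the scatter), concerns a methyl on an aromatic carbon and is modest. Compounds 1 and 2 differ in two places at once, so their values alone say nothing about the fluoro itself. With so little to go on, the step in this assay from compound 1 to compound 4 is expected to be small, and none beyond the scatter is assumed: a 1.1-fold lower number from compound 1 to compound 4 (0.03 log units; within the scatter). Compound 4 is therefore estimated at 650 nM, within a range from 250 nM to 1700 nM.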

Compound 4, half-maximal inhibitory concentration: 800 nM
The estimate for compound 4 lay 1.2-fold (0.09 log units) below the measured number; the measured number falls inside the stated range.
By their numbers in this assay, from the lowest: compounds 1 and 4 (each within the scatter of the next); then compound 3; then compound 2.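

In this assay the change from phenyl to 4-fluorophenyl, with fluoro on an aromatic carbon para to a large group, gives a 1.1-fold higher number from compound 1 to compound 4 (0.06 log units; within the scatter) and so leaves the number within the scatter. With the 4-fluorophenyl held fixed, the group on the saturated ring carbon does make a difference beyond the scatter: 3,4-dichlorophenyl in place of phenyl gives a 5.3-fold lower number from compound 2 to compound 4 (0.72 log units; beyond the scatter) and in place of 4-methylphenyl gives a 2.3-fold lower number from compound 3 to compound 4 (0.35 log units; beyond the scatter) in the same assay. No other data accompany these numbers to account for them.

Among these compounds, the fluoro step is seen only with 3,4-dichlorophenyl on the saturated ring carbon, so whether it stays as small with phenyl there remains open. Also open, as far as these compounds go, is how a methoxy, an amine or a carboxylic acid in place of the fluoro would read.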